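Lengthening an Amine Chain by One Carbon

This account rests on a few compounds, and the source may have more. Where it says the series, first, only, none or still open, it means among the compounds named here.

Three compounds share one core and differ only in the length of the amine chain. Compound 1 `COc1cc(C(=O)/C=C/c2ccc(OCCCNCCCNCCCCNCCCN)cc2)cc(OC)c1OC` carries the longest chain; in a functional assay on PC-3 cells (Homo sapiens) for antiproliferative activity, read by MTT assay, with a stated time of 48 h (a higher number here means a weaker inhibitor, a lower number a stronger inhibitor), compound 1 gives 14000 nM. Compound 2 `COc1cc(C(=O)/C=C/c2ccc(OCCCNCCCNCCCCN)cc2)cc(OC)c1OC` gives 13700 nM in this assay, and compound 3 `COc1cc(C(=O)/C=C/c2ccc(OCCCNCCCN)cc2)cc(OC)c1OC` gives 20400 nM. Compound 3 stands at the top of the three numbers, but every step between them lies inside the usual spread: a 1.0-fold lower number from compound 1 to compound 2 (0.01 log units; within the scatter), a 1.5-fold higher number from compound 1 to compound 3 (0.16 log units; within the scatter) and a 1.5-fold higher number from compound 2 to compound 3 (0.17 log units; within the scatter). Cutting away large pieces of the chain left the read-out essentially unchanged.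

Compound 4 `COc1cc(C(=O)/C=C/c2ccc(OCCCNCCCCN)cc2)cc(OC)c1OC` is not yet measured. It differs from compound 3 by aminomethyl in place of amino on a saturated chain carbon, three bonds along the chain from an amine nitrogen; read one bond further out, the change is 3-aminopropyl to 4-aminobutyl. Those larger trimmings moved nothing beyond the scatter. For this smaller change, no step beyond the scatter is expected either: a 1.2-fold lower number from compound 3 to compound 4 (0.08 log units; within the scatter). Compound 4 is therefore estimated at 17000 nM in this assay, with a range from 8000 nM to 36000 nM.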

Compound 4, half-maximal inhibitory concentration: 20100 nM
The estimate for compound 4 lay 1.2-fold (0.07 log units) below the measured number; the measured number falls inside the stated range.
By their numbers in this assay, from the lowest: compounds 2, 1, 4 and 3 (each within the scatter of the next).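

In this assay, the added carbon produces no change that can be told from the scatter (a 1.0-fold lower number from compound 3 to compound 4 (0.01 log units; within the scatter)). The one-carbon change of aminomethyl in place of amino therefore behaves like the larger trimmings seen earlier, now tested at the short end of the chain. Compound 4 also stays within the scatter of both longer-chain compounds, even though (4-aminobutyl)amino (a 1.5-fold higher number from compound 2 to compound 4 (0.17 log units; within the scatter)) and (4-((3-aminopropyl)amino)butyl)amino (a 1.4-fold higher number from compound 1 to compound 4 (0.16 log units; within the scatter)) are much larger pieces than the single carbon.

Still open, going by these compounds, is whether the read-out would stay this level with a shorter 2-aminoethyl chain, or with a carboxylic acid in place of the amino group at the end of the chain. Nothing measured alongside these compounds says why the number stays so level across these chains.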